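From Isopropyl to Acetyl on the Shared Core

A few compounds are considered here, and "the series" means these few. Any claim that something is new, unique, unknown or untested is made for them only; others in the source may bear on it.

Compound 2 `CC(C)c1cccc(NC(=O)N[C@@H](C)c2ccccc2)c1` gives 86% in an ADME assay on the whole organism with Oryza sativa as the target, tested at 10 uM (on this read-out higher numbers stand for a weaker effect at the one concentration tested and lower numbers for a stronger effect), the second highest of the three numbers recorded. Its stereoisomer compound 1 `CC(C)c1cccc(NC(=O)N[C@H](C)c2ccccc2)c1` gives 44%, and the step of a number 42 percentage points higher from compound 1 to compound 2 (beyond the scatter) rests on (the fact that compounds 1 and 2 differ only in the configuration as drawn). Compound 3 `C[C@H](NC(=O)Nc1ccccc1C(F)(F)F)c1ccccc1` gives 97%; compounds 2 and 3 differ in more than one place, so their two values stand only side by side. The next compound, compound 4 `CC(=O)c1cccc(NC(=O)N[C@@H](C)c2ccccc2)c1`, differs from compound 2 in a single place: acetyl in place of isopropyl on an aromatic carbon. Going by the values given here, no measured step exchanges one aromatic substituent for another, so the one known step, which concerns configuration alone, does not bear on this change. On this basis compound 4 is expected to give 80% in this assay, between 55% and 100%. The step expected is a number 6 percentage points lower from compound 2 to compound 4 (within the scatter).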

Compound 4, a percentage reported as activity, at one concentration (the size of the read-out at that concentration, not a potency): 94%
Compound 4: the middle estimate sits 14 percentage points below what was measured; the measured number falls inside the stated range.
By their numbers in this assay, from the lowest: compound 1; then compounds 2, 4 and 3 (each within the scatter of the next, the first and the last beyond it).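

In this assay, acetyl in place of isopropyl on an aromatic carbon, meta to a large group, comes to a number 8 percentage points higher from compound 2 to compound 4 (within the scatter), so in the configuration drawn for compound 2 the read-out does not separate these two groups at this position. No available information bears on why this exchange reads as it does. Still open, as far as these compounds go, is whether an amine or a carboxylic acid at this position would stand apart from both groups. Also open, from the compounds shown here alone, is how acetyl would read in the configuration of compound 1, which gives 44% with isopropyl.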